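The compounds below may be only part of what the source reports. "The series", "measured", "known", "first", "only" and "open" are said of these compounds alone.

Two compounds have so far been run in an assay on nucleic acid for binding affinity to Quadruplex DNA (Homo sapiens), read by fluorescence, tested at 20 uM; on this read-out higher numbers stand for stronger stabilisation of the target against heat and lower numbers for weaker stabilisation of the target. Compound 1 `Cc1ccc(COc2ccc(CNCC3CCNCC3)cc2)cc1` gives 1.3 degrees C in this assay. Compound 2 `CC(C)(N)C(=O)NC1CCN(C(=O)Cn2ccc3ccncc32)CC1` gives 0.6 degrees C in this assay; the two numbers sit within the usual scatter of each other, so compound 2 stands on a par with compound 1 rather than apart from it. For the measured compounds named here, no pairwise step between measured compounds is recorded. The next compound to be run is compound 3 `CC(C)CC(N)C(=O)NC1CCN(C(=O)Cn2ccc3ccncc32)CC1`, which differs from compound 2 by 1-amino-3-methylbutyl in place of 1-amino-1-methylethyl on a carbonyl carbon. Both measured shifts are small, and nothing in the series indicates that this change should move the read-out; the step from compound 2 to compound 3 is therefore expected to be a number 0.10 degrees C higher from compound 2 to compound 3 (within the scatter), none beyond the scatter. Compound 3 is accordingly estimated to give about 0.7 degrees C in this assay, with a plausible range from -0.5 degrees C to 2 degrees C.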

Compound 3, shift of the target's melting temperature: 0.1 degrees C
The estimate for compound 3 lay 0.60 degrees C above the measured number; the measured number falls inside the stated range.
By their numbers in this assay, from the lowest: compounds 3, 2 and 1 (each within the scatter of the next, the first and the last beyond it).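

In this assay the change from 1-amino-1-methylethyl to 1-amino-3-methylbutyl on a carbonyl carbon gives a number 0.50 degrees C lower from compound 2 to compound 3 (within the scatter) and provides the first step read at this position. Going from 4 to 6 heavy atoms, with the counts of hydrogen-bond donors and acceptors unchanged, therefore does not separate the two compounds on this read-out. No measurement to hand bears on why the two groups read alike.

From the compounds shown here alone, it remains open whether a carboxylic acid or a phenyl ring on this carbonyl carbon would give a step beyond the scatter. Going by these compounds, it is equally open whether a longer chain ending in an amine would do so, or whether this position tolerates such groups as it does the two branched amino chains.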